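Swapping a Benzyl Substituent: Bromine in Place of Methyl

The source may hold more compounds than are shown below. What is called first, only, known or untested is meant among the compounds shown, and "the series" means these compounds.

The three compounds share one core and differ only in what is attached to a saturated chain carbon bound to an amine nitrogen. Compound 1 `CNCc1c(OC)cc(Oc2cccc(Nc3ccccc3)c2)cc1OC` carries a hydrogen there; in a functional assay on HT-29 cells (Homo sapiens) for inhibition, read by MTT assay, with a stated time of 72 h (a lower number here means a stronger inhibitor, a higher number a weaker inhibitor), compound 1 gives 7430 nM, the highest number among the three. Compound 2 `COc1cc(Oc2cccc(Nc3ccccc3)c2)cc(OC)c1CNCc1ccc(C)cc1` carries a 4-methylphenyl at that place and gives 3880 nM, while compound 3 `COc1cc(Oc2cccc(Nc3ccccc3)c2)cc(OC)c1CNCc1ccc(O)cc1` carries a 4-hydroxyphenyl and gives 2180 nM. The step of a 1.9-fold lower number from compound 1 to compound 2 (0.28 log units; within the scatter) stays within the scatter, whereas the step of a 3.4-fold lower number from compound 1 to compound 3 (0.53 log units; beyond the scatter) is modest but real; between the two substituted compounds, a 1.8-fold lower number from compound 2 to compound 3 (0.25 log units; within the scatter) remains within the scatter.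

Compound 4 `COc1cc(Oc2cccc(Nc3ccccc3)c2)cc(OC)c1CNCc1ccc(Br)cc1` has not yet been measured. Relative to compound 1 the change is 4-bromophenyl in place of hydrogen on a saturated chain carbon bound to an amine nitrogen. Among the measured compounds shown here, the closest precedent is compound 2, since there too an aryl group without a hydroxy enters at the same place, and that step was a 1.9-fold lower number from compound 1 to compound 2 (0.28 log units; within the scatter); the step to compound 3 was somewhat larger. A lowering of about the same size as for compound 2 is therefore expected, with the outcome likely to stay close to the scatter. The expected step is a 2.3-fold lower number from compound 1 to compound 4 (0.35 log units; beyond the scatter), and compound 4 is estimated at 3300 nM, within a range from 1300 nM to 8500 nM.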

Compound 4, half-maximal inhibitory concentration: 3060 nM
Beside the measured number, compound 4's estimate is 1.1-fold (0.03 log units) above it; the measured number falls inside the stated range.
By their numbers in this assay, from the lowest: compounds 3, 4, 2 and 1 (each within the scatter of the next, the first and the last beyond it).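

In this assay, 4-bromophenyl gives a 2.4-fold lower number from compound 1 to compound 4 (0.39 log units; beyond the scatter), so a step beyond the scatter at this saturated chain carbon does not depend on a hydroxy, which compound 3 alone had suggested until now. The group on the aromatic carbon cannot be told apart on these numbers: bromo in place of hydroxy gives a 1.4-fold higher number from compound 3 to compound 4 (0.15 log units; within the scatter), and bromo in place of methyl gives a 1.3-fold lower number from compound 2 to compound 4 (0.10 log units; within the scatter), both within the scatter. Compound 2 goes against any simple rule that all three aryl groups clearly beat hydrogen, as a 1.9-fold lower number from compound 1 to compound 2 (0.28 log units; within the scatter) stays within the scatter even though compound 2 and compound 4 cannot be separated from each other.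

Nothing shown here gives a measured reason for these small differences. As far as these compounds go, it remains open whether an amine or a carboxylic acid on the aromatic carbon, a plain phenyl with no added group, or a longer chain between the amine nitrogen and the ring would move the number further than these modest steps.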